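The compounds below may be only part of what the source reports. "The series", "measured", "known", "first", "only" and "open" are said of these compounds alone.

Series notes. Compound 1 `Fc1cccc(F)c1Cc1cnc(Nc2ccc(Oc3ccncc3)c(Cl)c2)o1` and compound 2 `Fc1cccc(F)c1Cc1cnc(Nc2ccc(Oc3ccncc3)cc2)o1` share one core; compound 3 `OCc1ccc(Nc2ncc(Cc3c(F)cccc3F)o2)cc1Cl` and compound 4 `OCc1ccc(Nc2ncc(Cc3c(F)cccc3F)o2)cc1` share another. The two cores differ by hydroxymethyl in place of (pyridin-4-yl)oxy on an aromatic carbon. In an ADME assay on MT2 cells (Homo sapiens) for cytotoxicity, read by MTT assay (a higher number here means that more compound is tolerated, a lower number that less compound is tolerated), compound 1 gives 21000 nM, and compound 2 gives 21000 nM. These two differ by hydrogen in place of chloro on an aromatic carbon, a change that gave no change at the digits printed from compound 1 to compound 2 (within the scatter). In this assay compound 3 gives 90000 nM, which is a 4.3-fold higher number from compound 1 to compound 3 (0.63 log units; beyond the scatter). Among the three measured compounds, compound 3 has the highest number, its steps to compound 1 and to compound 2 both lying beyond the scatter.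

Compound 4 is not yet measured. It differs from compound 3 by hydrogen in place of chloro on an aromatic carbon. This is the same kind of change as that from compound 1 to compound 2, but not the same change: in compound 1 the chloro that leaves is ortho to a (pyridin-4-yl)oxy group, whereas in compound 3 it is ortho to a hydroxymethyl group; in both cases it is meta to a large group. Within the data shown here, the single measured instance of this kind of change, no change at the digits printed from compound 1 to compound 2 (within the scatter), shows no movement in this assay. On that basis the step from compound 3 to compound 4 is expected to be no change at the digits printed from compound 3 to compound 4 (within the scatter), resting on no change at the digits printed from compound 1 to compound 2 (within the scatter) alone. Compound 4 is therefore estimated at 90000 nM in this assay, with a range from 45000 nM to 180000 nM. Among the measured compounds shown here, only one measured pair supports the analogy, and compound 3 at 90000 nM already sits at the high end of the measured numbers, so the range is kept wide.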

Compound 4, half-maximal cytotoxic concentration: > 100000 nM
Compound 4 was reported as a limit; the forecaster's own chance of this, stated with the estimate: 20%; middle value at least 1.1-fold (0.04 log units) away from the limit.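

In this assay compound 4 is reported as > 100000 nM, which is a limit of the assay and not a number: the limit of > 100000 nM in this assay, at which 1 of the 4 values shown sits. Hydrogen in place of chloro gives an at least 1.1-fold higher number from compound 3 to compound 4 (0.04 log units; that floor lies within the scatter), so this change shows no step beyond the scatter on either core, although the limit does not show that the change is equally silent on the core of compound 3, where the true step could be larger: the same change on two cores in this assay, no change at the digits printed (within the scatter) from compound 1 to compound 2 and an at least 1.1-fold higher number (0.04 log units; that floor lies within the scatter) from compound 3 to compound 4; the limit leaves it open whether they differ. Hydroxymethyl in place of (pyridin-4-yl)oxy gives an at least 4.7-fold higher number from compound 2 to compound 4 (0.67 log units; beyond the scatter), so the higher number seen with the chloro group present also appears with hydrogen in its place, but the size of the step on the two cores cannot be compared: the same change on two cores in this assay, a 4.3-fold higher number (0.63 log units; beyond the scatter) from compound 1 to compound 3 and an at least 4.7-fold higher number (0.67 log units; beyond the scatter) from compound 2 to compound 4; the limit leaves it open whether they differ.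

These two pairs leave open whether either change would carry over to a further core. They also leave open how the number would move with an amine, a carboxylic acid or a longer chain in place of the hydroxymethyl group, or with bromo or methyl in place of the chloro group.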